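The source may report more compounds than this note shows. Statements on the series, on what has been measured and on what is new or still open speak of the compounds shown alone.

Of the compounds shown here, three built on related frameworks have been tested in a functional assay on K562 cells (Homo sapiens) for cytotoxicity, read by MTT assay, with a stated time of 5 days; a lower number here means a stronger inhibitor, a higher number a weaker inhibitor: compound 1 `COc1ccc(Cn2nncc2-c2cc(OC)c(OC)c(OC)c2)cc1[N+](=O)[O-]`, compound 2 `COc1ccc(-c2cn(-c3cc(OC)c(OC)c(OC)c3)nn2)cc1[N+](=O)[O-]` and compound 3 `COc1ccc(Cn2cc(-c3cc(OC)c(OC)c(OC)c3)nn2)cc1O`. Compound 1 gives > 10000 nM, which is a limit of the assay and not a number. Compound 2 gives > 10000 nM, again a limit. Compound 3 gives > 10000 nM, also a limit. Compound 3 thus stands with the other two at the limit of > 10000 nM in this assay, at which 3 of the 3 values shown sit, and the data give no order among them.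

The next compound, compound 4 `COc1ccc(Cn2cc(-c3cc(OC)c(OC)c(OC)c3)nn2)cc1N`, departs from compound 3 in one place: amino in place of hydroxy on an aromatic carbon. The 3-hydroxy-4-methoxyphenyl group becomes 3-amino-4-methoxyphenyl, with amino in place of hydroxy on an aromatic carbon, ortho to a methoxy group. Within the data shown here, no measured pair in this small set shows what a single change of this kind does in this assay. The expectation therefore rests only on compound 3 at > 10000 nM, a limit that leaves the starting point open. A small shift toward stronger inhibition is thought possible, but a reading at the same limit is the likeliest result. The expected size of the change is a step that the limit leaves unreadable from compound 3 to compound 4. The estimate for compound 4 is 12000 nM, with an expected range from 2000 nM to 50000 nM.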

Compound 4, half-maximal inhibitory concentration: > 10000 nM
Compound 4 was reported as a limit (the forecaster's own chance of this, stated with the estimate: 70%); the middle value does not contradict the limit.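

Compound 3 and compound 4 both stand at a limit of this assay, so the exchange of hydroxy for amino gives no step that can be read: the limit of > 10000 nM in this assay, at which 4 of the 4 values shown sit.

The compounds shown leave open how these four rank against one another and which change, if any, would give a measured number in this assay.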